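A few compounds are considered here, and "the series" means these few. Any claim that something is new, unique, unknown or untested is made for them only; others in the source may bear on it.

Working notes on the series.

Two compounds carry measured numbers. Compound 1 `CCc1cc(Nc2nc(N[C@@H](C)c3cccc(F)c3)nc3ccccc23)n[nH]1` is the weaker of the pair: in an assay on isolated protein for inhibition of G protein-coupled receptor kinase 6 (Homo sapiens), read by scintillation counting, radiometric assay and 33P incorporation, with a stated time of 80 min, in the presence of a further agent that is not named here (on this read-out lower numbers stand for stronger inhibition and higher numbers for weaker inhibition), compound 1 gives 340 nM, the highest of the two numbers recorded. Compound 2 `CCc1cc(Nc2nc(NCc3ccc(Cl)cc3)nc3cccc(OC)c23)n[nH]1` differs from compound 1 in several places at once, and in this assay compound 2 gives 16 nM; the gap between the two lies well beyond the usual scatter, but since the two structures differ in more than one place, no single change can be read from it.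

Compound 3 `CCc1cc(Nc2nc(N[C@H](C)c3ccc(F)cc3)nc3ccccc23)n[nH]1` has not yet been measured. It differs from compound 1 only in the side group on the ring nitrogen: 1-(4-fluorophenyl)ethyl in place of 1-(3-fluorophenyl)ethyl on a nitrogen on an aromatic ring. The two have the same atoms, joined differently, and the rest of the shared core is untouched.

Among the compounds with values here, no measured pair in the set isolates this kind of change, so there is no precedent to lean on. For compound 3 the expected step in this assay is a 1.2-fold higher number from compound 1 to compound 3 (0.07 log units; within the scatter), a shift not expected to exceed the scatter in either direction. Compound 3 is therefore estimated at 400 nM in this assay, with a range from 150 nM to 1100 nM.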

Compound 3, half-maximal inhibitory concentration: 1400 nM
Compound 3: the middle estimate sits 3.5-fold (0.54 log units) below what was measured, and the stated range ends below it.
By their numbers in this assay, from the lowest: compound 2; then compound 1; then compound 3.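

In this assay, within the data shown here, putting 1-(4-fluorophenyl)ethyl in place of 1-(3-fluorophenyl)ethyl on a nitrogen on an aromatic ring gives a 4.1-fold higher number from compound 1 to compound 3 (0.61 log units; beyond the scatter), the first change that can be read at a single place. This position therefore responds to an exchange that keeps the same atoms and the same counts, so the side group on this nitrogen is not interchangeable with its isomer. The two structures also write their defined stereocentre in opposite senses, so the step belongs to the exchange as a whole and cannot be assigned to the place of the fluorine alone, and nothing at hand bears on why the number moves.

Still open, from the compounds shown here alone, is whether a 1-phenylethyl group without fluorine, or an amine or a pyridine ring in the side group, would keep or lose inhibition at this position. Going by these compounds, compound 2 differs from compound 1 and compound 3 in several places, so it remains unknown whether the same exchange would give a step of similar size on a core carrying a methoxy group.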